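This account rests on a few compounds, and the source may have more. Where it says the series, first, only, none or still open, it means among the compounds named here.

In an in vitro ADME assay on microsomes from liver (Simiiformes) (on this read-out lower numbers stand for a shorter-lived compound and higher numbers for a longer-lived compound), compound 3 (`COCc1cc(CCCOc2c(C)cc(-c3noc(C)n3)cc2C)on1`) gives 0.5 h. Compound 1 (`CCc1cc(CCCOc2c(C)cc(-c3noc(C)n3)cc2C)on1`) gives 0.183 h, which leaves compound 3 with the higher of the two actual numbers. Compound 2 (`Cc1cc(-c2noc(C(F)(F)F)n2)cc(C)c1OCCCc1cccc(F)n1`), which carries 6-fluoropyridin-2-yl, reads > 2.5 h, and this is a limit of the assay.

Compound 4 (`Cc1nc(-c2cc(C)c(OCCCc3cccc(F)n3)c(C)c2)no1`) differs from compound 3 on a saturated chain carbon, three bonds along the chain from an oxygen on an aromatic ring: 6-fluoropyridin-2-yl in place of 3-(methoxymethyl)-1,2-oxazol-5-yl on a saturated chain carbon, three bonds along the chain from an oxygen on an aromatic ring. Among the measured compounds shown here, the one measured step that bears on this change is a 2.7-fold higher number from compound 1 to compound 3 (0.44 log units; beyond the scatter), a modest step that lies within the group now leaving. For the measured compounds named here, no measured step replaces that whole group, so this step offers only a rough guide to size. The direction rests on compound 2 and its limit of > 2.5 h, although compound 2 also differs from compound 4 elsewhere. A rise in this assay is therefore expected, of modest size, and it is estimated as a 2.2-fold higher number from compound 3 to compound 4 (0.34 log units; beyond the scatter). Compound 4 is estimated at 1.1 h, with an expected range from 0.45 h to 2.5 h.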

Compound 4, half-life: 0.283 h
Compound 4: the middle estimate sits 3.9-fold (0.59 log units) above what was measured; measured number below the stated range.
By their numbers in this assay, from the lowest: compounds 1, 4 and 3 (each within the scatter of the next, the first and the last beyond it). At a limit, above all of these: compound 2.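

In this assay, 6-fluoropyridin-2-yl on this saturated chain carbon gives a 1.8-fold lower number from compound 3 to compound 4 (0.25 log units; within the scatter) in place of 3-(methoxymethyl)-1,2-oxazol-5-yl and a 1.5-fold higher number from compound 1 to compound 4 (0.19 log units; within the scatter) in place of 3-ethyl-1,2-oxazol-5-yl, so on these steps the fluoropyridine alone does not set compound 4 apart from either compound. The long-lived reading of compound 2 goes instead with the other place of difference, where methyl in place of trifluoromethyl on an aromatic carbon gives an at least 8.8-fold lower number from compound 2 to compound 4 (0.94 log units; beyond the scatter). Compound 2 stands at a limit, so that step has only a lower bound: the limit of > 2.5 h in this assay, at which 1 of the 4 values shown sits.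

Still open, from the compounds shown here alone, is whether trifluoromethyl on that aromatic carbon gives a step of similar size with either 1,2-oxazole group on the chain. Also open, going by these compounds, is how a difluoromethyl group or a nitrile would read in that place.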